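Compound 2 to compound 4: replacing the pyridin-2-yl group

The compounds below may be only part of what the source reports. "The series", "measured", "known", "first", "only" and "open" are said of these compounds alone.

Of the compounds shown here, three have been measured so far in an ADME assay on Caco-2 cells (Homo sapiens) for permeability, read by LC-MS, in the apical to basolateral direction, with a stated time of 60 min, at pH 6.5; on this read-out lower numbers stand for lower permeability and higher numbers for higher permeability. Compound 1 (`Cc1cccc([C@@H](O)C(=O)N2N=CC[C@H]2C(=O)NCc2cc(Cl)ccc2-n2cnnn2)c1`) gives 9.7 10^-6 cm/s and compound 3 (`O=C(NCc1cc(Cl)ccc1-n1cnnn1)[C@@H]1CCNN1C(=O)[C@H](O)c1ccccc1`) gives 5.3 10^-6 cm/s there. Compound 2 (`O=C(NCc1cc(Cl)ccc1-n1cnnn1)[C@@H]1[C@@H]2C[C@@H]2CN1C(=O)[C@H](O)Cc1ccccn1`) gives 0.62 10^-6 cm/s and is the lowest of the three, with the gaps to both others beyond the scatter.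

Compound 4 (`CC1(C[C@@H](O)C(=O)N2C[C@H]3C[C@H]3[C@H]2C(=O)NCc2cc(Cl)ccc2-n2cnnn2)CC1`) has 1-methylcyclopropyl in place of pyridin-2-yl on a saturated chain carbon, two bonds along the chain from a carbonyl carbon and an oxygen on a saturated carbon and is otherwise unchanged from compound 2.

Within the data shown here, no measured pair differs in one place only, so the size of this change in this assay has no direct precedent. The three compounds differ in several places at once, and none of them isolates this exchange. Among the measured compounds shown here, the only guide is that compound 2 (0.62 10^-6 cm/s) sits at the bottom of the measured range, which leaves more room above it than below. A moderate rise, probably just beyond the scatter, is therefore expected, though no change beyond the scatter cannot be excluded. The expected size is a 3.2-fold higher number from compound 2 to compound 4 (0.51 log units; beyond the scatter) on this estimate. For compound 4 the estimated value is 2 10^-6 cm/s with an expected range from 0.6 10^-6 cm/s to 6.5 10^-6 cm/s in this series.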

Compound 4, apparent permeability: 2.2 10^-6 cm/s
Estimate against measurement, compound 4: 1.1-fold (0.04 log units) below; low and high end bracket the measured number.
By their numbers in this assay, from the lowest: compound 2; then compound 4; then compounds 3 and 1 (each within the scatter of the next).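

In this assay, 1-methylcyclopropyl in place of pyridin-2-yl gives a 3.5-fold higher number from compound 2 to compound 4 (0.55 log units; beyond the scatter). Among these compounds, this is the first step that differs in one place only, and it shows that the read-out responds to the group carried on this saturated chain carbon, though the step is modest. The exchange changes several things at once, from a six-membered aromatic ring with 1 hetero atom and 1 hydrogen-bond acceptor to a three-membered ring of carbon only with 0 acceptors, and no measurement at hand assigns the rise to any one of these differences.

Among the compounds shown here, the single step leaves open whether the loss of the ring nitrogen, the change of ring or the change from 6 heavy atoms to 4 accounts for the rise, and a tert-butyl or a cyclohexyl group at the same place would help to separate these. It also leaves open whether an amine or a carboxylic acid on this chain would move the number further, and whether the same exchange would give a similar step on the other cores in the series.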